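Working notes: macrophage tolerance of halophenyl analogues

This account rests on a few compounds, and the source may have more. Where it says the series, first, only, none or still open, it means among the compounds named here.

Measured so far:
- compound 1 `c1ccc(Cc2nnc(Cn3nnc4ccccc43)o2)cc1`: in an ADME assay on cells (Macrophage, Homo sapiens) for inhibition (a higher number here means that more compound is tolerated, a lower number that less compound is tolerated), compound 1 gives > 100000 nM, a limit of the assay.
- compound 2 `Brc1cccc(-c2nnc(Cn3nnc4ccccc43)o2)c1`: in this assay compound 2 gives > 100000 nM, a limit.
- compound 3 `Brc1ccc(-c2nnc(Cn3nnc4ccccc43)o2)cc1`: in this assay compound 3 gives > 100000 nM, a limit.

Compound 3 thus stands where all three values sit, at the limit of > 100000 nM in this assay, at which 3 of the 3 values shown sit. The measured steps a step that the two limits leave unreadable from compound 1 to compound 2, a step that the two limits leave unreadable from compound 1 to compound 3 and a step that the two limits leave unreadable from compound 2 to compound 3 are all unreadable, so no step size can be drawn from them.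

Compound 4 `Clc1cccc(-c2nnc(Cn3nnc4ccccc43)o2)c1` differs from compound 3 by 3-chlorophenyl in place of 4-bromophenyl on an aromatic carbon. With every step unreadable, no movement beyond the scatter in this assay is expected for compound 4; most likely the assay again reports only a limit. Compound 4 is therefore estimated at 100000 nM, between 50000 nM and 200000 nM. The expected step is a number no higher from compound 3 to compound 4 (the limit leaves the size open).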

Compound 4, half-maximal cytotoxic concentration: > 100000 nM
Compound 4 was reported as a limit; the forecaster's own chance of this, stated with the estimate: 85%; the middle value sits exactly at the limit.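

The steps to compound 4 from compound 1, compound 2 and compound 3 cannot be read, as all four compounds sit at one limit: the limit of > 100000 nM in this assay, at which 4 of the 4 values shown sit. The compounds shown leave open where any of the four truly lies in this assay, and whether any of these changes moves tolerance at all.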